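Replacing the Sulfonate Oxygen Link with a Nitrogen Link

This account rests on a few compounds, and the source may have more. Where it says the series, first, only, none or still open, it means among the compounds named here.

Compound 1 `Cc1ccccc1OS(=O)(=O)c1ccc(NC(=O)NCCCCl)cc1` was tested in a functional assay on HT-29 cells (Homo sapiens) for cytotoxicity, read by sulforhodamine B assay, with a stated time of 48 h (a higher number here means a weaker inhibitor, a lower number a stronger inhibitor), where compound 1 gives 26000 nM. Its only measured relative, compound 2 `CCc1ccccc1OS(=O)(=O)c1ccc(NC(=O)NCCCCl)cc1`, carries a methyl in place of hydrogen on a saturated chain carbon bound to an aromatic carbon; in this assay compound 2 gives 15000 nM. That change brought a 1.7-fold lower number from compound 1 to compound 2 (0.24 log units; within the scatter), so the two values cannot be told apart, and compound 1 stands together with compound 2 rather than above or below it.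

The compound now of interest is compound 3 `Cc1ccccc1NS(=O)(=O)c1ccc(NC(=O)NCCCCl)cc1`, which differs from compound 1 in one place: (2-methylphenyl)amino in place of 2-methylphenoxy on a sulfonyl sulfur. Within the data shown here, no measured pair changes this part of the molecule, so there is no step in the data that bears directly on it; the single measured step concerns a different position and was itself within the scatter. With nothing to push the expectation either way, the change is expected to give a 1.2-fold lower number from compound 1 to compound 3 (0.07 log units; within the scatter), that is, no shift beyond the scatter, but with wide uncertainty because the link between the sulfonyl sulfur and the ring is new. Compound 3 is therefore estimated at 22000 nM, with a range from 5000 nM to 90000 nM.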

Compound 3, half-maximal inhibitory concentration: 64000 nM
Estimate against measurement, compound 3: 2.9-fold (0.46 log units) below, within the range that was stated.
By their numbers in this assay, from the lowest: compounds 2 and 1 (each within the scatter of the next); then compound 3.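

In this assay, swapping the oxygen link on the sulfonyl sulfur for a nitrogen link brings a 2.5-fold higher number from compound 1 to compound 3 (0.39 log units; beyond the scatter), a modest step but one that, unlike the earlier methyl change on the saturated chain carbon, lies beyond the scatter. This shows that the link joining the aromatic ring to the sulfonyl sulfur can alter the cytotoxicity reading even when the size of the group stays the same: both groups have the same heavy-atom count and the same aromatic ring, and the entering group has a nitrogen in place of the oxygen, with a hydrogen-bond donor where the leaving group has an acceptor. Nothing measured here explains why the nitrogen link gives the higher number.

One open question is whether a methylene link on the sulfonyl sulfur, or an N-methyl-substituted nitrogen link, would stay with compound 1 or move further in the direction of compound 3. Also open, going by these compounds, is whether (2-ethylphenyl)amino would show the same shift, since a single pair cannot show whether the effect of this link holds with a different group on the ring.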